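From methoxymethyl to a halogenated phenyl on the shared core

A few compounds are considered here, and "the series" means these few. Any claim that something is new, unique, unknown or untested is made for them only; others in the source may bear on it.

Compound 1 `CCOCCOC(=O)C(=O)Nc1nc(-c2cc(Cl)no2)cs1`: 6 mg/kg
Compound 2 `CCOCCOC(=O)C(=O)Nc1nc(-c2cc(OC)no2)cs1`: 3 mg/kg
Compound 3 `CCOCCOC(=O)C(=O)Nc1nc(-c2cc(COC)no2)cs1`: 2.4 mg/kg

In a functional assay on the whole organism with Rattus norvegicus as the target (a lower number here means that less compound is needed, a higher number that more compound is needed for the effect), compound 3 gives 2.4 mg/kg. Two measured steps lead to it: a 1.3-fold lower number from compound 2 to compound 3 (0.10 log units; within the scatter), and a 2.5-fold lower number from compound 1 to compound 3 (0.40 log units; beyond the scatter). Compound 4 `CCOCCOC(=O)C(=O)Nc1nc(-c2cc(-c3c(F)cccc3Cl)no2)cs1` carries 2-chloro-6-fluorophenyl in place of methoxymethyl on an aromatic carbon. The third measured step at this place, a 2.0-fold lower number from compound 1 to compound 2 (0.30 log units; within the scatter), is also small. None of these compounds carries a ring there, so the measured steps are only a loose guide and the direction stays uncertain. A modest step is still the best expectation, with a slight lean upward in this assay. The expected change is a 1.7-fold higher number from compound 3 to compound 4 (0.22 log units; within the scatter). For compound 4 the estimated value is 4 mg/kg, within a range of 1.2 mg/kg to 13 mg/kg.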

Compound 4, dose for half-maximal effect: 1.1 mg/kg
Compound 4: the middle estimate sits 3.6-fold (0.56 log units) above what was measured; measured number outside the range, below it.
By their numbers in this assay, from the lowest: compound 4; then compounds 3, 2 and 1 (each within the scatter of the next, the first and the last beyond it).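

A ring is tolerated at this position: in this assay, moving to 2-chloro-6-fluorophenyl gives a 2.2-fold lower number from compound 3 to compound 4 (0.34 log units; beyond the scatter), a 2.7-fold lower number from compound 2 to compound 4 (0.44 log units; beyond the scatter) and a 5.5-fold lower number from compound 1 to compound 4 (0.74 log units; beyond the scatter), each beyond the scatter. Compound 4 therefore needs the lowest dose of the four compounds, and the earlier non-ring groups gave no sign of this. No measurement here explains the gain. Going by these compounds, it remains open whether the ring alone is enough or whether its chlorine and fluorine matter. A plain phenyl, or a phenyl carrying an amine, would separate these possibilities.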